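From ethyl to difluoromethyl in compound 3

The source may hold more compounds than are shown below. What is called first, only, known or untested is meant among the compounds shown, and "the series" means these compounds.

Measured values in an ADME assay (Rattus norvegicus) for pharmacokinetics (on this read-out higher numbers stand for wider distribution into tissues and lower numbers for narrower distribution), are these
Compound 1 `C=C[C@@H]1C[C@]1(NC(=O)[C@@H]1[C@H](CC)[C@@H]2CN1C(=O)[C@H](C(C)(C)C)NC(=O)O[C@@H]1C[C@H]1CCCCCc1nc3ccc(OC)cc3nc1O2)C(=O)NS(=O)(=O)C1CC1` gives 1.9 L/kg
Compound 2 `CC[C@@H]1[C@@H]2CN(C(=O)[C@H](C(C)(C)C)NC(=O)O[C@@H]3C[C@H]3CCCCCc3nc4ccc(OC)cc4nc3O2)[C@@H]1C(=O)N[C@]1(C(=O)NS(=O)(=O)C2CC2)C[C@H]1CC` gives 3.1 L/kg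

Compound 2 at 3.1 L/kg sits within the scatter of compound 1, so neither stands apart. Compound 3 `CC[C@@H]1[C@@H]2CN(C(=O)[C@H](C(C)(C)C)NC(=O)O[C@@H]3C[C@H]3CCCCCc3nc4ccc(OC)cc4nc3O2)[C@@H]1C(=O)N[C@]1(C(=O)NS(=O)(=O)C2CC2)C[C@H]1C(F)F` is not yet measured. It differs from compound 2 by difluoromethyl in place of ethyl on a saturated ring carbon and in words that is difluoromethyl in place of ethyl on a saturated ring carbon. Within the data shown here, the one measured step on such a carbon is a 1.6-fold higher number from compound 1 to compound 2 (0.21 log units; within the scatter) with ethyl in place of vinyl, and it lies within the scatter. Among the measured compounds shown here, no measured compound carries difluoromethyl, so that single step is thin support. In this assay the expected change is a 1.2-fold lower number from compound 2 to compound 3 (0.08 log units; within the scatter) and no step beyond the scatter is expected. For compound 3 the estimate is 2.6 L/kg and the expected range runs from 1.4 L/kg to 4.8 L/kg on this estimate.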

Compound 3, volume of distribution at steady state in the Rattus norvegicus assay: 1 L/kg
Compound 3: the middle estimate sits 2.6-fold (0.41 log units) above what was measured; the whole stated range lies above it.
By their numbers in the Rattus norvegicus assay, from the lowest: compounds 3, 1 and 2 (each within the scatter of the next, the first and the last beyond it).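

Among these compounds, in the Rattus norvegicus assay, difluoromethyl in place of ethyl gives a 3.1-fold lower number from compound 2 to compound 3 (0.49 log units; beyond the scatter), the first step at this saturated ring carbon to pass the scatter, whereas difluoromethyl in place of vinyl gives a 1.9-fold lower number from compound 1 to compound 3 (0.28 log units; within the scatter). In a physicochemical assay for lipophilicity (a lower number here means a more polar compound, a higher number a more lipophilic compound), compound 2 gives 4.6 and compound 3 gives 3.5. A possible cause of the narrower distribution is lower lipophilicity, since in the physicochemical assay the same ethyl change leaves compound 3 more polar than compound 2: the measured distribution coefficient of compound 2, 4.6, and of compound 3, 3.5, a number 1.10 log units lower (beyond the scatter)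

On these data alone, what a trifluoromethyl or hydroxymethyl group on this carbon would do remains open. So does whether the two read-outs move together beyond this single pair.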